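Moving a Trifluoromethyl Group Around a Benzyl Ether

The source may hold more compounds than are shown below. What is called first, only, known or untested is meant among the compounds shown, and "the series" means these compounds.

Measured compounds:
Compound 1, `C=CCOc1ccc2c(=O)c(-c3cc(OC)c(OC)cc3OC)coc2c1`: 4750 nM
Compound 2, `COc1cc(OC)c(-c2coc3cc(OCc4ccc([N+](=O)[O-])cc4)ccc3c2=O)cc1OC`: > 10000 nM (a limit)
Compound 3, `COc1cc(OC)c(-c2coc3cc(OCc4ccccc4C(F)(F)F)ccc3c2=O)cc1OC`: > 10000 nM (a limit)

In a functional assay on A-375 cells (Homo sapiens) for antiproliferative activity, read by MTT assay, with a stated time of 24 h (a higher number here means a weaker inhibitor, a lower number a stronger inhibitor), compound 1 gives 4750 nM. Compound 2 reaches only the limit of > 10000 nM. Compound 3 likewise reaches only the limit of > 10000 nM, so compound 3 stands at the weak end of what was measured, and its true number is not known; note (the limit of > 10000 nM in this assay, at which 2 of the 3 values shown sit).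

The measured steps are an at least 2.1-fold higher number from compound 1 to compound 2 (0.32 log units; beyond the scatter) and an at least 2.1-fold higher number from compound 1 to compound 3 (0.32 log units; beyond the scatter), while a step that the two limits leave unreadable from compound 2 to compound 3.

Compound 4, `COc1cc(OC)c(-c2coc3cc(OCc4ccc(C(F)(F)F)cc4)ccc3c2=O)cc1OC`, differs from compound 3 by 4-(trifluoromethyl)phenyl in place of 2-(trifluoromethyl)phenyl on a saturated chain carbon bound to an oxygen on an aromatic ring.

Both known steps that put an aryl group on the saturated chain carbon ended at the limit, and the change to compound 4 keeps the same aryl group, only rearranged. The step from compound 3 is therefore expected to be small or unreadable, a step that the limit leaves unreadable from compound 3 to compound 4. Compound 4 is estimated at 12000 nM, within a range of 4000 nM to 40000 nM.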

Compound 4, half-maximal inhibitory concentration: 2280 nM
Beside the measured number, compound 4's estimate is 5.3-fold (0.72 log units) above it, outside the stated range (below it).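

At this position the same atoms can give different results: moving from 2-(trifluoromethyl)benzyl to 4-(trifluoromethyl)benzyl gives an at least 4.3-fold lower number from compound 3 to compound 4 (0.64 log units; beyond the scatter) in this assay, so an aryl group on this saturated chain carbon does not by itself end at the limit. The other group on that ring counts too, with an at least 4.3-fold lower number from compound 2 to compound 4 (0.64 log units; beyond the scatter), and against the vinyl group the 4-(trifluoromethyl)phenyl gives a 2.1-fold lower number from compound 1 to compound 4 (0.32 log units; beyond the scatter), so an aryl group here can beat vinyl, as compound 4 does, or fall short of it, as compound 2 and compound 3 do. The steps that start from compound 2 and compound 3 show only a minimum size, as both of these compounds sit at a limit: the limit of > 10000 nM in this assay, at which 2 of the 4 values shown sit.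

Going by these compounds, what a chlorine, an amine or a carboxylic acid would do in place of the trifluoromethyl group stays open. So does how far past the limit compound 2 and compound 3 really lie.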